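A few compounds are considered here, and "the series" means these few. Any claim that something is new, unique, unknown or untested is made for them only; others in the source may bear on it.

Among the measured compounds shown here, in a functional assay on T47D cells (Homo sapiens) for cytotoxicity, read by CCK-8 assay (on this read-out higher numbers stand for weaker inhibition and lower numbers for stronger inhibition), compound 2 `Oc1cccc(-c2cc(-c3ccccn3)cc(-c3ccccc3O)n2)c1` gives 2560 nM, the only actual number among the two values recorded, so it stands alone as a measured point. Compound 1 `Oc1ccc(-c2cc(-c3ccsc3)cc(-c3ccccc3O)n2)cc1` reaches only the limit of the assay at > 50000 nM, which is not a number but a boundary, the situation summarized as the limit of > 50000 nM in this assay, at which 1 of the 2 values shown sits. Compound 3 `Oc1ccc(-c2cc(-c3ccccn3)cc(-c3ccccc3O)n2)cc1` has not yet been tested in this assay. It carries the same atoms as compound 2 joined differently: 4-hydroxyphenyl in place of 3-hydroxyphenyl on an aromatic carbon. For the measured compounds named here, no step between two measured compounds is recorded, so the size of this change cannot be read from the data. The expectation is that the step from compound 2 to compound 3 in this assay is a 1.3-fold higher number from compound 2 to compound 3 (0.10 log units; within the scatter), amounting to no change beyond the usual scatter in either direction. Compound 3 is therefore estimated at 3200 nM in this assay, with a range from 1000 nM to 12000 nM.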

Compound 3, half-maximal inhibitory concentration: > 50000 nM
Compound 3 was reported as a limit; the forecaster's own chance of this, stated with the estimate: 12%; middle value at least 15-fold (1.19 log units) from the limit.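

In this assay, the group on the aromatic carbon next to the ring nitrogen proves sensitive to how its hydroxyl is placed: 4-hydroxyphenyl in place of 3-hydroxyphenyl gives an at least 19-fold higher number from compound 2 to compound 3 (1.29 log units; beyond the scatter). Among the compounds shown here, this is the first readable step, and it shows that two groups with the same atoms are not interchangeable at this position, with the 3-hydroxyphenyl group of compound 2 giving the only actual number so far. Compound 3 joins compound 1 at a limit of the assay rather than at a number: the limit of > 50000 nM in this assay, at which 2 of the 3 values shown sit.

The step from compound 1 to compound 3 cannot be read, so pyridin-2-yl and thiophen-3-yl remain uncompared. Also open, going by these compounds, is whether a methoxy group or an amine in place of the hydroxyl of the 3-hydroxyphenyl group would retain a measurable value.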